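Benzofuranyl hydrazone series: antiproliferative read-out on MCF7 cells

The compounds below may be only part of what the source reports. "The series", "measured", "known", "first", "only" and "open" are said of these compounds alone.

Measured so far:
- compound 1 `COc1ccc(-c2csc(N/N=C(\C)c3cc4ccccc4o3)n2)cc1`: 18900 nM
- compound 2 `CCOC(=O)Cc1csc(N/N=C(\C)c2cc3ccccc3o2)n1`: 6550 nM

In a functional assay on MCF7 cells (Homo sapiens) for antiproliferative activity (on this read-out lower numbers stand for stronger inhibition and higher numbers for weaker inhibition), compound 1 gives 18900 nM, and compound 2 gives 6550 nM; the step of a 2.9-fold lower number from compound 1 to compound 2 (0.46 log units; beyond the scatter) is the only one in hand. Compound 2 therefore stands at the lowest of the two numbers, with compound 1 the nearest and higher.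

Compound 3 `C/C(=N\Nc1nc(-c2cc3ccccc3o2)cs1)c1cc2ccccc2o1` differs from compound 2 by 1-benzofuran-2-yl in place of (ethoxycarbonyl)methyl on an aromatic carbon. Within the data shown here, the one measured step, a 2.9-fold lower number from compound 1 to compound 2 (0.46 log units; beyond the scatter), shows that removing an aromatic group from this position in favour of the ester-bearing chain gave a modest fall; compound 3 puts an aromatic group back at the same position, so a step of similar size in the opposite direction is the plain expectation, with wide uncertainty since the two aromatic groups are not the same. The expected step is a 1.8-fold higher number from compound 2 to compound 3 (0.26 log units; within the scatter). For compound 3 the estimate in this assay is 12000 nM, within a range of 4000 nM to 40000 nM.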

Compound 3, half-maximal inhibitory concentration: 25600 nM
For compound 3 the middle estimate is 2.1-fold (0.33 log units) below the measured one; measured number inside the range.
By their numbers in this assay, from the lowest: compound 2; then compounds 1 and 3 (each within the scatter of the next).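

In this assay, 1-benzofuran-2-yl in place of (ethoxycarbonyl)methyl gives a 3.9-fold higher number from compound 2 to compound 3 (0.59 log units; beyond the scatter) and so the lower number of the ester-bearing chain at this position, next to the ring nitrogen, now holds against two different aromatic groups rather than 4-methoxyphenyl alone. Exchanging one aromatic group for the other gives a 1.4-fold higher number from compound 1 to compound 3 (0.13 log units; within the scatter) and so 4-methoxyphenyl and 1-benzofuran-2-yl are not told apart here, despite the added ring. No available data explain the difference between the chain and the aromatic groups.

With only one non-aromatic group shown, it remains open whether the lower number follows the ester itself or simply the absence of an aromatic ring at this position. A carboxylic acid, a primary amide or a plain propyl chain there would separate these two readings.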